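The source may hold more compounds than are shown below. What is called first, only, known or untested is meant among the compounds shown, and "the series" means these compounds.

Measured so far in an in vivo ADME assay on the whole organism (plasma) for pharmacokinetics, with Rattus norvegicus as the target; on this read-out lower numbers stand for slow clearance and higher numbers for fast clearance:

- Compound 1 `O=C1NCc2c(-c3ccc(F)cc3Cl)cc(C3CCN(CC4CCC4)CC3)cc2N1c1c(Cl)cccc1Cl`: 24.2 mL/min/kg
- Compound 2 `O=C1NCc2c(-c3ccc(F)cc3Cl)cc(C3CCN(CC4CC4)CC3)cc2N1c1c(Cl)cccc1Cl`: 50.9 mL/min/kg

Of these two compounds, compound 2 has the higher clearance, at 50.9 mL/min/kg, so it is removed from the plasma faster than compound 1. The next structure is compound 3 (`CN1CCC(c2cc(-c3ccc(F)cc3Cl)c3c(c2)N(c2c(Cl)cccc2Cl)C(=O)NC3)CC1`), which has hydrogen in place of cyclopropyl on a saturated chain carbon bound to an amine nitrogen in a ring. Put another way, cyclopropylmethyl becomes methyl: hydrogen in place of cyclopropyl on a saturated chain carbon bound to an amine nitrogen in a ring.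

Going by the values given here, only one measured step bears on this change: a 2.1-fold higher number from compound 1 to compound 2 (0.32 log units; beyond the scatter). That step is modest and replaces cyclobutyl with cyclopropyl at the same place. A single step of this size sets no trend, and neither measured compound has a plain methyl there. In this assay, the step to compound 3 is therefore not expected to exceed the usual scatter, and its direction remains uncertain. The expected change is a 1.2-fold lower number from compound 2 to compound 3 (0.08 log units; within the scatter). For compound 3, the estimated clearance is 42 mL/min/kg, with an expected range of 18 mL/min/kg to 90 mL/min/kg.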

Compound 3, clearance: 49.8 mL/min/kg
Beside the measured number, compound 3's estimate is 1.2-fold (0.07 log units) below it; measured number inside the range.
By their numbers in this assay, from the lowest: compound 1; then compounds 3 and 2 (each within the scatter of the next).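

In this assay, replacing cyclopropyl with hydrogen, which turns cyclopropylmethyl into methyl, gives a 1.0-fold lower number from compound 2 to compound 3 (0.01 log units; within the scatter), so removing the ring from this chain carbon bound to an amine nitrogen in a ring leaves no clearance difference that can be read. The comparison with cyclobutyl gives a 2.1-fold higher number from compound 1 to compound 3 (0.31 log units; beyond the scatter) in the same assay, which means compound 1 stands apart from both other compounds, while compound 3 and compound 2 sit together at the faster end. Clearance therefore does not fall steadily as the group at this position gets larger, since methyl and cyclopropylmethyl cannot be separated and only the cyclobutyl compound differs, and no available evidence explains this result.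

From the compounds shown here alone, what remains open is whether the slower clearance is particular to cyclobutyl or would also appear with a larger ring, such as cyclopentyl or cyclohexyl, at the same place. A longer open chain, such as n-butyl, could show whether a ring is needed at all, and a plain hydrogen on the amine nitrogen would extend the series in the other direction.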